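Formyl(methyl)amino in place of cyclopropylmethylamino on a purine-like core

This account rests on a few compounds, and the source may have more. Where it says the series, first, only, none or still open, it means among the compounds named here.

Measured compounds:
- compound 1 `CNc1ncnc2c1ncn2Cc1cccc(F)c1`: 7 mg/kg
- compound 2 `CNc1ncnc2c1ncn2Cc1c(F)cccc1Cl`: 12.5 mg/kg
- compound 3 `Fc1ccccc1Cn1cnc2c(NCC3CC3)ncnc21`: 4.3 mg/kg

Three compounds share a core and differ in the group on the ring carbon and in the substituted benzyl group. In a functional assay on the whole organism with Rattus norvegicus as the target, in the maximal electroshock model (a lower number here means that less compound is needed, a higher number that more compound is needed for the effect), compound 1 gives 7 mg/kg, compound 2 gives 12.5 mg/kg, and compound 3 gives 4.3 mg/kg. Compound 3 has the lowest number of the three, but its gap to compound 1 lies within the scatter, so the two cannot be ranked; only the gap from compound 3 to compound 2 lies beyond the scatter.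

Compound 4 `CN(C=O)c1ncnc2c1ncn2Cc1ccccc1F` has not been measured. It differs from compound 3 in one place: formyl(methyl)amino in place of (cyclopropylmethyl)amino on an aromatic carbon. The hydrogen-bond donor of compound 3 is lost, and a formyl group is carried on the nitrogen instead of the three-membered ring.

Within the data shown here, no measured pair shows this kind of change, so the size of the step is uncertain. In this assay compound 4 is expected to need somewhat more compound, an estimated 12 mg/kg with a range from 5 mg/kg to 30 mg/kg; this expected step, a 2.8-fold higher number from compound 3 to compound 4 (0.45 log units; beyond the scatter), would be modest and near the edge of the scatter.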

Compound 4, dose for half-maximal effect: 11 mg/kg
For compound 4 the middle estimate is 1.1-fold (0.04 log units) above the measured one; the measured number falls inside the stated range.
By their numbers in this assay, from the lowest: compounds 3, 1, 4 and 2 (each within the scatter of the next, the first and the last beyond it).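

In this assay, among these compounds, the change at this aromatic carbon gives a 2.6-fold higher number from compound 3 to compound 4 (0.41 log units; beyond the scatter), the first comparison here between compounds that differ in one place. The step shows that a compound without a hydrogen-bond donor on this nitrogen, and without the three-membered ring, still gives a measurable effect in this whole-animal model, though more of it is needed. No measurement here offers an explanation for the size of this step.

From the compounds shown here alone, the swap removes the donor and the ring and adds the formyl group all at once, so the share of each in the step stays open. Dimethylamino or (cyclopropylmethyl)(methyl)amino at this place, with the same fluorobenzyl group as compound 3, would help to separate these parts, and a longer chain on the nitrogen would show how much room for variation this position allows.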